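Half-life notes: 4-carboxyphenyl to 4-isopropylpiperazin-1-yl

The source may report more compounds than this note shows. Statements on the series, on what has been measured and on what is new or still open speak of the compounds shown alone.

In an ADME assay (liver) for metabolic stability, with Liver microsome (Homo sapiens) as the target, using microsomes (on this read-out higher numbers stand for a longer-lived compound and lower numbers for a shorter-lived compound), compound 2 `CCc1nc2cc(Cl)ccn2c1C(=O)NCc1ccc(-c2ccc(C(=O)O)cc2)cc1` gives > 2 h as a limit of the assay and not a number. Compound 2 thus stands at the limit of > 2 h in this assay, at which 1 of the 2 values shown sits, and has no exact reading. Compound 1 `CCCc1nc2ccccn2c1C(=O)NCc1ccc(-c2ccccc2)cc1` gives a measured 0.373 h in this assay and carries no 4-carboxyphenyl group. Going by the values given here, no two measured compounds differ in one place only, so no measured step guides the next change. In compound 3 `CCc1nc2cc(Cl)ccn2c1C(=O)NCc1ccc(N2CCN(C(C)C)CC2)cc1` 4-isopropylpiperazin-1-yl stands in place of 4-carboxyphenyl on an aromatic carbon, para to a large group 4-isopropylpiperazin-1-yl in place of 4-carboxyphenyl on an aromatic carbon in the structure. Among the compounds with values here, compound 1 at 0.373 h is the only numeric guide, so a step towards shorter life, beyond the scatter, is expected. The expected change is an at least 3.3-fold lower number from compound 2 to compound 3 (0.52 log units; beyond the scatter) by this estimate. Estimated for compound 3 in this assay is 0.6 h with a range of 0.2 h to 1.8 h expected.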

Compound 3, half-life: > 2 h
Compound 3: only a limit was reported; the forecaster's own chance of this, stated with the estimate: 15%; at least 3.3-fold (0.52 log units) between middle value and limit.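

No step can be read from compound 2 to compound 3, since both are reported only as limits of the assay: the limit of > 2 h in this assay, at which 2 of the 3 values shown sit. The compounds shown leave open how long compound 2 and compound 3 actually last, and whether their half-lives differ at all.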